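Halogen swap on the nitro-bearing core, compound 2 to 3

The compounds below may be only part of what the source reports. "The series", "measured", "known", "first", "only" and "open" are said of these compounds alone.

Measured so far:
- compound 1 `Cc1ccc(/C=C2\CCC/C(=C\c3ccc([N+](=O)[O-])cc3)C2=O)cc1`: in a functional assay on MOLT-4 cells (Homo sapiens) for cytotoxicity, with a stated time of 72 h (on this read-out lower numbers stand for stronger inhibition and higher numbers for weaker inhibition), compound 1 gives 8440 nM
- compound 2 `O=C1/C(=C/c2ccc(F)cc2)CCC/C1=C\c1ccc([N+](=O)[O-])cc1`: in this assay compound 2 gives 17100 nM

Compound 2 holds the higher of the two numbers; its nearest neighbour is compound 1, with a 2.0-fold higher number from compound 1 to compound 2 (0.31 log units; beyond the scatter). Compound 3 `O=C1/C(=C/c2ccc(Cl)cc2)CCC/C1=C\c1ccc([N+](=O)[O-])cc1` carries the change (chloro in place of fluoro on an aromatic carbon). Among the measured compounds shown here, the only measured step, a methyl to fluoro exchange at the same place, was modest, so for compound 3 no change beyond the scatter is expected, a 1.4-fold lower number from compound 2 to compound 3 (0.15 log units; within the scatter). The estimate for compound 3 in this assay is 12000 nM, range 5000 nM to 30000 nM.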

Compound 3, half-maximal inhibitory concentration: 9120 nM
For compound 3 the middle estimate is 1.3-fold (0.12 log units) above the measured one; measured number inside the range.
By their numbers in this assay, from the lowest: compounds 1, 3 and 2 (each within the scatter of the next, the first and the last beyond it).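

Chloro in place of fluoro at this place, on an aromatic carbon para to a large group, gives in this assay a 1.9-fold lower number from compound 2 to compound 3 (0.27 log units; within the scatter), and chloro in place of methyl gives a 1.1-fold higher number from compound 1 to compound 3 (0.03 log units; within the scatter). Chloro therefore lies within the scatter of both other groups, although the methyl to fluoro step, a 2.0-fold higher number from compound 1 to compound 2 (0.31 log units; beyond the scatter), lies just beyond it. No measured evidence bears on the reason for these readings.

Open, going by these compounds, is whether an amine or a carboxylic acid at this place would give a larger step. Also open, on these data alone, is whether the chloro and fluoro exchange reads the same with an amine in place of the nitro group.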